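From Diethylcarbamoyl to Methyl-oxadiazolyl: Estimating Compound 4

The compounds below may be only part of what the source reports. "The series", "measured", "known", "first", "only" and "open" are said of these compounds alone.

Among the compounds with values here, compound 1 `CCN(CC)C(=O)[C@@H]1CCCN(S(=O)(=O)c2ccc(S(=O)(=O)N(CC)CC)cc2)C1` gives 6400 nM in a functional assay on MIA PaCa-2 cells (Homo sapiens) for inhibition, read by MTT assay, with a stated time of 7 days (on this read-out lower numbers stand for stronger inhibition and higher numbers for weaker inhibition), the highest of the three numbers measured so far. Compound 2 `CCN(CC)S(=O)(=O)c1ccc(S(=O)(=O)N2CCC[C@@H](C(=O)NC3CN(C(=O)OC(C)(C)C)C3)C2)cc1` gives 200 nM and compound 3 `CCN(CC)S(=O)(=O)c1ccc(S(=O)(=O)N2CCC[C@@H](C(=O)NC3CN(C(=O)NC(C)(C)C)C3)C2)cc1` gives 3400 nM. Compound 4 `CCN(CC)S(=O)(=O)c1ccc(S(=O)(=O)N2CCC[C@@H](c3nc(C)no3)C2)cc1` differs from compound 1 by 3-methyl-1,2,4-oxadiazol-5-yl in place of diethylcarbamoyl on a saturated ring carbon. The measured steps all alter what sits on that carbonyl carbon: a 32-fold lower number from compound 1 to compound 2 (1.51 log units; beyond the scatter), a 1.9-fold lower number from compound 1 to compound 3 (0.27 log units; within the scatter) and a 17-fold higher number from compound 2 to compound 3 (1.23 log units; beyond the scatter). They show that the outcome at this position swings widely, but none of them removes the carbonyl and sets an aromatic ring in its place, so the expected step is uncertain. A modest improvement, a 2.1-fold lower number from compound 1 to compound 4 (0.33 log units; beyond the scatter), is estimated. Compound 4 is expected to give about 3000 nM, within a range from 800 nM to 12000 nM.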

Compound 4, half-maximal inhibitory concentration: 4100 nM
Compound 4: middle estimate off by 1.4-fold (0.14 log units), on the low side, within the range that was stated.
By their numbers in this assay, from the lowest: compound 2; then compounds 3, 4 and 1 (each within the scatter of the next).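

In this assay, replacing diethylcarbamoyl with 3-methyl-1,2,4-oxadiazol-5-yl gives a 1.6-fold lower number from compound 1 to compound 4 (0.19 log units; within the scatter). This is the first step shown that removes the carbonyl from the saturated ring carbon and puts an aromatic ring there, and the number stays within the scatter. Nothing measured here explains this result.

On these data alone, it remains open how the number would respond to a longer chain in place of the methyl on the aromatic ring. A carboxylic acid or an amine on the same saturated ring carbon is also an open case.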